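Working notes: from compound 2 to compound 4

The source may report more compounds than this note shows. Statements on the series, on what has been measured and on what is new or still open speak of the compounds shown alone.

Compound 2 `CN(C)CCNc1nc(-c2ccc(NC(=O)Nc3ccc(F)cc3)cc2)nc2c(Cl)c(Cl)sc12` has been measured in a functional assay on MKN-45 cells (Homo sapiens) for cytotoxicity, read by MTT assay, with a stated time of 72 h (a lower number here means a stronger inhibitor, a higher number a weaker inhibitor), where compound 2 gives 1350 nM. Among the three measured numbers it stands second highest; its nearest neighbour is compound 1 `CN(C)CCCNc1nc(-c2ccc(NC(=O)Nc3ccc(F)cc3)cc2)nc2c(Cl)c(Cl)sc12`, which gives 1120 nM, and the furthest is compound 3 `CN(C)CCNc1nc(-c2ccc(NC(=O)Nc3ccc(Cl)cc3Cl)cc2)nc2ccsc12`, which gives 2360 nM. Going by the values given here, the single measured step in this set, a 1.2-fold higher number from compound 1 to compound 2 (0.08 log units; within the scatter), shows that a change on the amine-bearing chain leaves the number inside the scatter.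

Compound 4 `CN(C)CCNc1nc(-c2ccc(NC(=O)Nc3ccc(Cl)cc3Cl)cc2)nc2c(Cl)c(Cl)sc12` differs from compound 2 by 2,4-dichlorophenyl in place of 4-fluorophenyl on an amide-type nitrogen. Among the compounds with values here, no measured step carries this exact change on the shared core. Compound 3 bears the same 2,4-dichlorophenyl group, but its core also differs from that of compound 2, so the two values cannot be read as the urea-aryl change alone; what they show is a gap that stays within the scatter. The expected step is accordingly small, a 1.1-fold higher number from compound 2 to compound 4 (0.05 log units; within the scatter), with no confident direction. Compound 4 is estimated to give about 1500 nM, with a likely range from 600 nM to 4000 nM.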

Compound 4, half-maximal inhibitory concentration: 3460 nM
Beside the measured number, compound 4's estimate is 2.3-fold (0.36 log units) below it, within the range that was stated.
By their numbers in this assay, from the lowest: compounds 1, 2, 3 and 4 (each within the scatter of the next, the first and the last beyond it).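

Going by these compounds alone, on the shared core, 2,4-dichlorophenyl in place of 4-fluorophenyl on an amide-type nitrogen gives the only step in this assay that lies beyond the scatter, a 2.6-fold higher number from compound 2 to compound 4 (0.41 log units; beyond the scatter), a modest move towards a weaker inhibitor. Within the data shown here, the one earlier step, on the amine-bearing chain, stayed within the scatter, so this aryl group is the place where a single change has so far moved the number. This rests on one pair of compounds, and no supporting data bear on the reason for the shift.

Open, on these data alone, is whether the step follows from gaining the chlorines or from losing the fluorine, and a plain phenyl on the same nitrogen would help separate the two. Also open, as far as these compounds go, is whether the change carries over to a chain ending in morpholine instead of dimethylamino.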